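The compounds below may be only part of what the source reports. "The series", "measured", "known", "first", "only" and "open" are said of these compounds alone.

Compound 1, `COC(=O)c1cccc(NC(=O)COc2ccc(C)cc2)c1`: in an assay for inhibition of malate dehydrogenase, cytoplasmic (Homo sapiens), with a stated time of 30 min (a higher number here means a weaker inhibitor, a lower number a stronger inhibitor), compound 1 gives > 40000 nM, which is a limit of the assay and not a number.
Compound 2, `COC(=O)c1ccc(O)c(NC(=O)CCCOc2ccc(C(C)(C)CC(C)(C)C)cc2)c1`: in this assay compound 2 gives 5160 nM.
Compound 3, `CCCc1ccc(OCC(=O)Nc2cccc(C(=O)OC)c2)cc1`: in this assay compound 3 gives > 40000 nM, again a limit rather than a number.

Compound 3 therefore stands at the limit of > 40000 nM in this assay, at which 2 of the 3 values shown sit, where compound 1 also sits. Going by the values given here, the one measured step that reaches compound 3, a step that the two limits leave unreadable from compound 1 to compound 3, joins two limits and so has no readable size. Among the compounds with values here, compound 2 differs from compound 3 in several places at once, so its number offers no single step to lean on.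

Compound 4 is `CCCCCc1ccc(OCC(=O)Nc2cccc(C(=O)OC)c2)cc1`. It differs from compound 3 by ethyl in place of hydrogen on a saturated chain carbon, three bonds along the chain from an aromatic carbon. Within the data shown here, the only step on a nearby chain, a step that the two limits leave unreadable from compound 1 to compound 3, showed that growing the chain left the limit untouched, so a further growth is expected to do the same: the step of a number no higher from compound 3 to compound 4 (the limit leaves the size open) is expected to stay within the scatter, most likely leaving compound 4 at a limit too. The estimate for compound 4 is 40000 nM, with a range from 8000 nM to 150000 nM.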

Compound 4, half-maximal inhibitory concentration: 6790 nM
For compound 4 the middle estimate is 5.9-fold (0.77 log units) above the measured one; measured number outside the range, below it.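

Before this result, the only step on this chain joined two limits and had no readable size. Now the same kind of growth, ethyl in place of hydrogen on a saturated chain carbon, three bonds along the chain from an aromatic carbon, gives a readable effect in this assay (an at least 5.8-fold lower number from compound 3 to compound 4 (0.77 log units; beyond the scatter)), and the longer growth of the same chain does too (an at least 5.8-fold lower number from compound 1 to compound 4 (0.77 log units; beyond the scatter)). Both sizes are only lower bounds, and each starts from a value that is a limit of the assay: the limit of > 40000 nM in this assay, at which 2 of the 4 values shown sit.

From the compounds shown here alone, the true size of either step stays open. Also open, going by these compounds, is whether a longer chain such as heptyl, a branched chain, or a chain ending in an amine or a carboxylic acid would lower the number further.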